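Taking the cyano group away: what compound 3 may show

The compounds below may be only part of what the source reports. "The series", "measured", "known", "first", "only" and "open" are said of these compounds alone.

Of the compounds shown here, two have been measured so far. In a functional assay on a cell-free system (plasma, Oryctolagus cuniculus) for inhibition, with stated times of 5 min, 1 min and 6 min (on this read-out lower numbers stand for stronger inhibition and higher numbers for weaker inhibition), compound 1 (`CCOC(=O)c1c(C)nc(-c2ccccc2C#N)n1OC`) gives 14900 nM and compound 2 (`CCOC(=O)c1c(C)nc(-c2ccc(C#N)cc2)n1OC`) gives 13400 nM on the same read-out. These two numbers lie within the usual scatter of each other, so compound 2 stands level with compound 1 and neither can be ranked above the other. The unmeasured compound 3 (`CCOC(=O)c1c(C)nc(-c2ccccc2)n1OC`) departs from compound 2 in one place. The change is hydrogen in place of cyano on an aromatic carbon and amounts to hydrogen in place of cyano on an aromatic carbon. Within the data shown here, both measured compounds carry a cyano group, so no measured pair shows directly what its loss does. With nothing to point either way, only a small shift is expected, and a 1.0-fold higher number from compound 2 to compound 3 (0.02 log units; within the scatter) is estimated to stay within the scatter in this assay without a clear direction. In this assay compound 3 is expected at 14000 nM with an estimated range of 6000 nM to 32000 nM around that middle value.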

Compound 3, half-maximal inhibitory concentration: > 30000 nM
Compound 3: a limit, no number; the forecaster's own chance of this, stated with the estimate: 10%; middle value at least 2.1-fold (0.33 log units) from the limit.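

In this assay compound 3 gives a limit and not a number: the limit of > 30000 nM in this assay, at which 1 of the 3 values shown sits. Hydrogen in place of cyano on the aromatic carbon para to a large group therefore weakens inhibition, with an at least 2.2-fold higher number from compound 2 to compound 3 (0.35 log units; beyond the scatter), and this step lies beyond the scatter. Among these compounds, it is the first sign that the cyano group matters at this position, which compound 1 and compound 2 could not show, as both carry that group and stand level with each other; the second comparison, with an at least 2.0-fold higher number from compound 1 to compound 3 (0.30 log units; that floor lies within the scatter), points the same way, but its floor lies within the scatter and so it does not establish a change on its own.

With only a floor known for each step, the full size of the loss remains open, and the compounds shown give no measured number for the unsubstituted ring. They also do not tell whether inhibition depends on the cyano group specifically, or whether another group at this position, such as an amine, a carboxylic acid or a methoxy group, would hold it equally well.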